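Solubility notes on the shared core: piperidinyl replacement

A few compounds are considered here, and "the series" means these few. Any claim that something is new, unique, unknown or untested is made for them only; others in the source may bear on it.

Compound 1 `Cn1cc(-c2cnc3[nH]cc(-c4ccc(O)cc4)c3c2)cn1`: in a physicochemical assay for solubility, read by LC-MS, in phosphate buffer, measured as thermodynamic solubility, with a stated time of 24 h, at pH 7.4 (on this read-out lower numbers stand for lower solubility and higher numbers for higher solubility), compound 1 gives < 3000 nM, which is a limit of the assay and not a number.
Compound 2 `Cn1cc(-c2cnc3[nH]cc(-c4cccnc4)c3c2)cn1`: in this assay compound 2 gives 97000 nM.

Among the values shown, compound 2 carries the only number; the other entry is a limit (the limit of < 3000 nM in this assay, at which 1 of the 2 values shown sits). Among the measured compounds shown here, the one measured step is large: an at least 32-fold higher number from compound 1 to compound 2 (1.50 log units; beyond the scatter). Compound 3 `Cn1cc(-c2cnc3[nH]cc(C4CCCNC4)c3c2)cn1` is not yet measured in this assay. It differs from compound 2 in a single place: piperidin-3-yl in place of pyridin-3-yl on an aromatic carbon of the five-membered ring, two ring bonds from the ring nitrogen. No measured step touches this change directly; the only step shown, from compound 1 to compound 2, exchanged one aromatic six-membered group for another and moved the number well beyond the scatter. The exchange here swaps an aromatic ring for a non-aromatic one bearing a hydrogen-bond donor, and the direction is read off nothing firmer than that single large step. The expectation is a rise beyond the scatter, of the size a 3.1-fold higher number from compound 2 to compound 3 (0.49 log units; beyond the scatter), and compound 3 is estimated at 300000 nM, within 80000 nM to 1500000 nM.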

Compound 3, solubility: 1000000 nM
Compound 3: middle estimate off by 3.3-fold (0.52 log units), on the low side; low and high end bracket the measured number.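

In this assay, the position keeps responding when the ring type changes and not only when one aromatic group replaces another: piperidin-3-yl in place of pyridin-3-yl gives a 10-fold higher number from compound 2 to compound 3 (1.01 log units; beyond the scatter), although the two groups match in heavy atoms and differ in the non-aromatic ring and the hydrogen-bond donor. Over the full span of groups shown at this aromatic carbon, piperidin-3-yl in place of 4-hydroxyphenyl gives an at least 330-fold higher number from compound 1 to compound 3 (2.52 log units; beyond the scatter), so three different six-membered groups at one place on the shared core are now separated by steps beyond the scatter. Compound 1 sits at a limit of the assay and not at a number, so the true size of that wider step stays unfixed: the limit of < 3000 nM in this assay, at which 1 of the 3 values shown sits.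

The compounds shown do not separate the loss of aromaticity from the gain of the ring amine hydrogen, and a cyclohexyl group, which has a non-aromatic ring without the nitrogen, would bear directly on that. From the compounds shown here alone, whether the step survives with a methyl group on the piperidine nitrogen, or with a morpholine ring in its place, also remains open.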